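Removing a Chloro Group on a Shared Amide Scaffold

This account rests on a few compounds, and the source may have more. Where it says the series, first, only, none or still open, it means among the compounds named here.

The study compares three measured compounds and one that has not yet been measured in a functional assay on A375P cells (Homo sapiens) for cytotoxicity, read by MTT assay; on this read-out higher numbers stand for weaker inhibition and lower numbers for stronger inhibition. Compound 1 `COC(=O)c1ccc2c(ccn2-c2ccc(NC(=O)c3ccc(Cl)c(C(F)(F)F)c3)cc2)n1` gives 3000 nM in this assay. Compound 2 `COC(=O)c1ccc2c(ccn2-c2ccc(NC(=O)c3cccc(C(F)(F)F)c3)cc2)n1` differs from compound 1 by hydrogen in place of chloro on an aromatic carbon and in this assay compound 2 gives 9500 nM, which is a 3.2-fold higher number from compound 1 to compound 2 (0.50 log units; beyond the scatter). Compound 3 `O=C(Nc1ccc(-n2ccc3nc(C(=O)NCc4ccccc4)ccc32)cc1)c1ccc(Cl)c(C(F)(F)F)c1` differs from compound 1 by benzylamino in place of methoxy on a carbonyl carbon, and in this assay compound 3 gives 700 nM, which is a 4.3-fold lower number from compound 1 to compound 3 (0.63 log units; beyond the scatter). Compound 3 thus stands lowest of the three numbers, beyond the scatter from both compound 1 and compound 2.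

Compound 4 `O=C(Nc1ccc(-n2ccc3nc(C(=O)NCc4ccccc4)ccc32)cc1)c1cccc(C(F)(F)F)c1` has not been measured. It differs from compound 3 by hydrogen in place of chloro on an aromatic carbon, the same change already made from compound 1 to compound 2. The surroundings of the place are described in the same words in both cases. The two cores differ as described by benzylamino in place of methoxy on a carbonyl carbon. On the strength of a 3.2-fold higher number from compound 1 to compound 2 (0.50 log units; beyond the scatter), the expected step is a 3.1-fold higher number from compound 3 to compound 4 (0.50 log units; beyond the scatter). That expectation rests on a single earlier step, from compound 1 to compound 2, and on a different core, so it carries real uncertainty. Compound 4 is therefore estimated at 2200 nM in this assay, with an expected range from 900 nM to 6000 nM.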

Compound 4, half-maximal inhibitory concentration: 3000 nM
For compound 4 the middle estimate is 1.4-fold (0.13 log units) below the measured one; the range from low to high includes it.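

In this assay, hydrogen in place of chloro on the 4-chloro-3-(trifluoromethyl)phenyl group gives a 4.3-fold higher number from compound 3 to compound 4 (0.63 log units; beyond the scatter), and this step agrees with the one seen earlier on the core of compound 1: the same change on two cores in this assay, a 3.2-fold higher number (0.50 log units; beyond the scatter) from compound 1 to compound 2 and a 4.3-fold higher number (0.63 log units; beyond the scatter) from compound 3 to compound 4, 1.4-fold (0.13 log units) apart, within the scatter of two such steps Read the other way, benzylamino in place of methoxy on a carbonyl carbon gives a 3.2-fold lower number from compound 2 to compound 4 (0.50 log units; beyond the scatter), and this step likewise agrees with its earlier counterpart, whether chloro or hydrogen is present: the same change on two cores in this assay, a 4.3-fold lower number (0.63 log units; beyond the scatter) from compound 1 to compound 3 and a 3.2-fold lower number (0.50 log units; beyond the scatter) from compound 2 to compound 4, 1.4-fold (0.13 log units) apart, within the scatter of two such steps Together, the four compounds show that in this assay each change carried over from one core to the other with little alteration in size, but this rests on a single pair of steps for each change, and it shows neither why the chloro group matters nor that the same would hold on any further core or in another assay.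

The compounds shown leave open whether a fluoro, bromo or methyl group in place of the chloro would give a step of similar size, and whether the trifluoromethyl group itself is needed. They also leave open how a carboxylic acid, or an amide built from a simple alkyl amine rather than benzylamine, would behave at the carbonyl carbon.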